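Shortening the side arm of compound 2

The source may report more compounds than this note shows. Statements on the series, on what has been measured and on what is new or still open speak of the compounds shown alone.

Measured compounds:
compound 1 `COc1ccc(-c2cn(C/C=C3\OC(=O)C(OCc4ccccc4)=C3OCc3ccccc3)nn2)cc1` — > 100000 nM
compound 2 `O=C1O[C@H]([C@@H](O)Cn2cc(CNS(=O)(=O)c3ccc(Cl)cc3F)nn2)C(OCc2ccccc2)=C1OCc1ccccc1` — 20700 nM
compound 3 `COc1ccccc1-c1cn(C/C=C2\OC(=O)C(OCc3ccccc3)=C2OCc2ccccc2)nn1` — > 100000 nM

In a functional assay on HeLa cells (Homo sapiens) for antiproliferative activity, read by MTT assay, with a stated time of 72 h (on this read-out lower numbers stand for stronger inhibition and higher numbers for weaker inhibition), compound 2 gives 20700 nM. Among the measured compounds shown here, this is the only number among the three measured values; the other two are limits of the assay. Compound 1 sits at the limit > 100000 nM. Compound 3 likewise sits at the limit > 100000 nM. For the measured compounds named here, the one measured step, a step that the two limits leave unreadable from compound 1 to compound 3, cannot be read in size, as the limit of > 100000 nM in this assay, at which 2 of the 3 values shown sit, covers both of its compounds.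

Compound 4 `O=C1O[C@H]([C@@H](O)Cn2cc(CCCCl)nn2)C(OCc2ccccc2)=C1OCc1ccccc1` is the unmeasured compound, and it differs from compound 2 in one place: 2-chloroethyl in place of ((4-chloro-2-fluorophenyl)sulfonyl)amino on a saturated chain carbon bound to an aromatic carbon. Going by the values given here, none of the measured steps bears on this kind of change; the only measured step is unreadable and concerns a different pair of compounds, so no size or direction can be taken from it. The expectation for compound 4 therefore rests on the value of compound 2 alone, with wide room on both sides. Compound 4 is estimated at 40000 nM, with a range from 10000 nM to 150000 nM. That estimate amounts to an expected 1.9-fold higher number from compound 2 to compound 4 (0.29 log units; within the scatter), a step whose direction is not fixed by any measured step here.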

Compound 4, half-maximal inhibitory concentration: 36700 nM
For compound 4 the middle estimate is 1.1-fold (0.04 log units) above the measured one; the measured number falls inside the stated range.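

On the saturated chain carbon bound to an aromatic carbon, putting 2-chloroethyl in place of ((4-chloro-2-fluorophenyl)sulfonyl)amino gives, in this assay, a 1.8-fold higher number from compound 2 to compound 4 (0.25 log units; within the scatter). Among the compounds shown here, this is the first step whose size can be read, and it shows that the whole group of 12 heavy atoms, with its six-membered aromatic ring and its hydrogen-bond donor, can give way to 3 heavy atoms with no ring while the two values stay within the scatter of each other. For the compounds shown here, the finding holds for this one pair and says only that the antiproliferative number of compound 2 does not depend on the sulfonyl-bearing aromatic group as far as this read-out can tell.

No measured property of these compounds bears on this step. As far as these compounds go, it remains open whether a primary amine, a carboxylic acid or a longer alkyl chain at this place would leave the number where it stands, and whether a plain ethyl group would do the same as 2-chloroethyl.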